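Furan-bearing series: phenyl in place of ethyl

The source may hold more compounds than are shown below. What is called first, only, known or untested is meant among the compounds shown, and "the series" means these compounds.

Two compounds have numbers in an assay on CHO cells for displacement of a labelled ligand from adenosine receptor A1 (Homo sapiens), with a stated time of 60 min, tested at 10 uM; on this read-out higher numbers stand for more inhibition at the one concentration tested (going by the name of the read-out) and lower numbers for less inhibition. Compound 1 `CCCOC(=O)C1=C(C)NC(=O)NC1c1ccco1` gives 43% in this assay. Compound 2 `CCOC(=O)C1=C(CC)NC(=O)NC1c1ccco1` gives 29% in this assay, the lowest of the two numbers; the nearest number, that of compound 1, sits higher by a gap beyond the scatter. Compound 3 `CCOC(=O)C1=C(c2ccccc2)NC(=O)NC1c1ccco1` differs from compound 2 by phenyl in place of ethyl on a double-bonded ring carbon. For the measured compounds named here, no measured pair shows a change of this kind, so its size is not known from the data; a modest rise is expected rather than none. Compound 3 is estimated at 38%, in the range 12% to 65%. The estimate means an expected step of a number 9 percentage points higher from compound 2 to compound 3 (within the scatter).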

Compound 3, a percentage reported as inhibition, at one concentration (the size of the read-out at that concentration, not a potency): 3%
Compound 3: the middle estimate sits 35 percentage points above what was measured, and the stated range ends above it.
By their numbers in this assay, from the lowest: compound 3; then compound 2; then compound 1.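

Replacing ethyl with phenyl on this double-bonded ring carbon gives a number 26 percentage points lower from compound 2 to compound 3 (beyond the scatter) in this assay. For the compounds shown here, this is the first one-place step, and it shows that the group at this position affects the read-out, with phenyl giving the lower number in this single pair. Nothing measured here accounts for the drop.

From the compounds shown here alone, a longer chain such as butyl, a benzyl group or an amine at this carbon remains open. So does whether phenyl has the same effect alongside the propyl ester of compound 1.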